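The source may hold more compounds than are shown below. What is called first, only, known or untested is meant among the compounds shown, and "the series" means these compounds.

Three compounds have so far been run through an ADME assay on microsomes from liver (Mus musculus) for metabolic stability, read by LC-MS, using NADPH, with a stated time of 45 min, tested at 0.5 uM; a lower number here means slower removal, a higher number faster removal of the compound. Compound 1, `O=C(CCSc1nc2cc(Cl)ccc2o1)N1CCS(=O)(=O)C1`, gives 8.9 mL/min/g; compound 2, `O=C(CCNc1nc2cc(Cl)ccc2o1)N1CCCC1`, gives 81.1 mL/min/g; compound 3, `O=C1CCCN1CCCSc1nc2cc(Cl)ccc2o1`, gives 51 mL/min/g. Compound 1 therefore stands lowest of the three, with compound 3 the nearest and compound 2 the furthest, and both gaps lie well beyond the usual scatter. Compound 4, `CC1CCCN1C(=O)CCSc1nc2cc(Cl)ccc2o1`, differs from compound 1 in one place: 2-methylpyrrolidin-1-yl in place of 1,1-dioxo-1,3-thiazolidin-3-yl on a carbonyl carbon. For the measured compounds named here, no measured pair shows this exact exchange, so any expectation rests only on the spread of the three numbers. Once the 1,1-dioxo-1,3-thiazolidin-3-yl group is exchanged for 2-methylpyrrolidin-1-yl, an upward step beyond the scatter is expected, a 4.5-fold higher number from compound 1 to compound 4 (0.65 log units; beyond the scatter). Compound 4 is estimated at about 40 mL/min/g, within a range from 12 mL/min/g to 120 mL/min/g.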

Compound 4, intrinsic clearance in a liver preparation (reported as CLH), per the amount of preparation that the assay uses: 98 mL/min/g
Beside the measured number, compound 4's estimate is 2.5-fold (0.39 log units) below it; the range from low to high includes it.
By their numbers in this assay, from the lowest: compound 1; then compounds 3, 2 and 4 (each within the scatter of the next).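

The exchange of 1,1-dioxo-1,3-thiazolidin-3-yl for 2-methylpyrrolidin-1-yl on a carbonyl carbon, with the rest of compound 1 unchanged, gives an 11-fold higher number from compound 1 to compound 4 (1.04 log units; beyond the scatter) in this assay and is a large step. This single place can therefore move the number a long way, and the low number of compound 1 depends on the group that leaves. Nothing available explains the size of this step.

Open, from the compounds shown here alone, is whether a morpholin-4-yl or dimethylamino group in this place would give a number like that of compound 1 or that of compound 4. Also open, going by these compounds, is whether the methyl of 2-methylpyrrolidin-1-yl plays any part in the step.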